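Reading a Methyl Step When the First Example Is Blind

The source may hold more compounds than are shown below. What is called first, only, known or untested is meant among the compounds shown, and "the series" means these compounds.

Compounds 1 and 2 share one core. Compound 1, `CN1C(=O)N(C)C2C1NC(=S)N2/N=C/C=C/c1ccccc1`, was tested in a functional assay on MCF7 cells (Homo sapiens) for inhibition, read by MTT assay, with a stated time of 72 h; a higher number here means a weaker inhibitor, a lower number a stronger inhibitor. In this assay compound 1 reaches only a limit of the assay, > 100000 nM, not a number. Compound 2, `CC(/C=N/N1C(=S)NC2C1N(C)C(=O)N2C)=C\c1ccccc1`, likewise gives only a limit in this assay, > 100000 nM. The change between the two is methyl in place of hydrogen on a double-bonded chain carbon bound to a carbon with a double bond to nitrogen and a double-bonded chain carbon. The step it made, a step that the two limits leave unreadable from compound 1 to compound 2, cannot be read because of the limit of > 100000 nM in this assay, at which 2 of the 3 values shown sit.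

Compound 3, `CCN1C(=O)N(CC)C2C1NC(=S)N2/N=C/C=C/c1ccccc1`, has another core; the difference between the two cores is not broken down here. In this assay, among the compounds with values here, compound 3 gives 36100 nM, the only real number among the measured values.

Compound 4, `CCN1C(=O)N(CC)C2C1NC(=S)N2/N=C/C(C)=C/c1ccccc1`, has not been measured. It differs from compound 3 by methyl in place of hydrogen on a double-bonded chain carbon bound to a carbon with a double bond to nitrogen and a double-bonded chain carbon, the same change as that from compound 1 to compound 2. Since that earlier example, a step that the two limits leave unreadable from compound 1 to compound 2, shows no readable size, the step from compound 3 to compound 4 in this assay is expected to be modest, a 1.4-fold higher number from compound 3 to compound 4 (0.14 log units; within the scatter), with wide uncertainty. Compound 4 is therefore estimated at 50000 nM, between 15000 nM and 200000 nM, with a real chance that this assay reports only a limit.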

Compound 4, half-maximal inhibitory concentration: 35100 nM
Compound 4: the middle estimate sits 1.4-fold (0.15 log units) above what was measured, within the range that was stated.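

In this assay, methyl in place of hydrogen on a double-bonded chain carbon bound to a carbon with a double bond to nitrogen and a double-bonded chain carbon gives a 1.0-fold lower number from compound 3 to compound 4 (0.01 log units; within the scatter), so on this core the methyl leaves the reading indistinguishable from that with hydrogen. This does not show that the change behaves the same way on both cores, because the matching step on the core of compound 1 cannot be read: the limit of > 100000 nM in this assay, at which 2 of the 4 values shown sit. The carry-over therefore rests on a single readable pair in one cell assay, which is too little to support a rule for the series.

The compounds shown hold only hydrogen or methyl at this chain carbon, so it remains open how a longer chain, such as propyl, or an amine would read there. Going by these compounds, it also remains open whether any change at this carbon can bring the core of compound 1 to a real number in this assay.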